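This account rests on a few compounds, and the source may have more. Where it says the series, first, only, none or still open, it means among the compounds named here.

Measured in a functional assay on HT-29 cells (Homo sapiens) for inhibition, read by sulforhodamine B assay, with a stated time of 72 h; a lower number here means a stronger inhibitor, a higher number a weaker inhibitor:
compound 1 `C=CC1C(=O)N(c2cc(OC)c(OC)c(OC)c2)C1c1ccc(SC)cc1`: 113 nM
compound 2 `C=CC1C(=O)N(c2cc(OC)c(OC)c(OC)c2)C1c1ccc(SCC)cc1`: 257 nM
compound 3 `C=CC1C(=O)N(c2cc(OC)c(OC)c(OC)c2)C1c1ccc(OC)cc1`: 10 nM

Compound 1, at 113 nM, holds the middle of the three numbers, with compound 2 higher and compound 3 lower. The next compound, compound 4 `COc1cc(N2C(=O)C(C3CC3)C2c2ccc(SC)cc2)cc(OC)c1OC`, differs from compound 1 as follows: cyclopropyl in place of vinyl on a saturated ring carbon. That is cyclopropyl in place of vinyl on a saturated ring carbon.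

For the measured compounds named here, no measured step touches this place, so the data give no direct measure of the change. The large steps, an 11-fold lower number from compound 1 to compound 3 (1.05 log units; beyond the scatter) and a 26-fold lower number from compound 2 to compound 3 (1.41 log units; beyond the scatter), replace the sulfur-bearing group on an aromatic carbon and bear on it only loosely. They show that the numbers in this series can move far. The nearest in kind is methyl in place of hydrogen, a 2.3-fold higher number from compound 1 to compound 2 (0.36 log units; beyond the scatter), which is modest and points to a weaker inhibitor. A modest rise in this assay is therefore expected, with wide uncertainty. The expected change is a 1.8-fold higher number from compound 1 to compound 4 (0.25 log units; within the scatter). For compound 4 the estimated value is 200 nM, with an expected range of 60 nM to 650 nM.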

Compound 4, half-maximal inhibitory concentration: 204 nM
For compound 4 the middle estimate is 1.0-fold (0.01 log units) below the measured one, within the range that was stated.
By their numbers in this assay, from the lowest: compound 3; then compounds 1, 4 and 2 (each within the scatter of the next, the first and the last beyond it).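

For the compounds shown here, this is the first reading at the saturated ring carbon of the four-membered ring: in this assay cyclopropyl in place of vinyl gives a 1.8-fold higher number from compound 1 to compound 4 (0.26 log units; within the scatter) and so stays inside the usual scatter. With the 4-(methylsulfanyl)phenyl group held constant, this carbon therefore takes a three-membered carbon ring in place of a double bond without a clear shift in the number, and the large steps in the series remain those on the aromatic carbon. Nothing shown here offers a reason for this result.

As far as these compounds go, it remains open whether cyclopropyl and vinyl also stay level when methoxy replaces methylsulfanyl on the aromatic carbon. Also open, from the compounds shown here alone, is how this ring carbon responds to other groups, such as a longer chain, a hydroxymethyl or an amine.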